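Compound 3 to compound 4: hydrogen in place of methyl

This account rests on a few compounds, and the source may have more. Where it says the series, first, only, none or still open, it means among the compounds named here.

In an ADME assay on H9c2 cells (Rattus norvegicus) for cytotoxicity, read by MTT assay, with a stated time of 48 h (a lower number here means a stronger inhibitor, a higher number a weaker inhibitor), compound 1 `COc1ccc(NC(=S)OCCNC(=O)C(C)(C)Oc2ccc(Cl)cc2)cc1` gives 747000 nM. Compound 3 `Cc1ccc(NC(=S)OCCNC(=O)C(C)(C)Oc2ccc(Cl)cc2)cc1` gives 771000 nM. Going by the values given here, the one measured step reads a 1.0-fold higher number from compound 1 to compound 3 (0.01 log units; within the scatter), so these two numbers stand level and compound 3 has no other numeric neighbour.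

For compound 2 `O=C(NCCOC(=S)Nc1ccccc1)c1cccnc1` the result in this assay is only a limit, > 800000 nM.

Compound 4 `CC(C)(Oc1ccc(Cl)cc1)C(=O)NCCOC(=S)Nc1ccccc1` follows from compound 3 with hydrogen in place of methyl on an aromatic carbon, para to a large group (hydrogen in place of methyl on an aromatic carbon). That is 4-methylphenyl to phenyl. The measured step above falls on the same aromatic carbon, where methyl stands in place of methoxy, and it stayed within the scatter. One step is thin support, but it gives no reason to expect a change beyond the scatter here, in either direction.

The expected step is a 1.0-fold lower number from compound 3 to compound 4 (0.00 log units; within the scatter). For compound 4 the estimated value is 770000 nM, with an expected range of 480000 nM to 1200000 nM.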

Compound 4, half-maximal inhibitory concentration: > 800000 nM
Compound 4 ended at the assay's limit; the forecaster's own chance of this, stated with the estimate: 35%; at least 1.0-fold (0.01 log units) between middle value and limit.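

In this assay, hydrogen on this aromatic carbon, para to a large group, yields steps with a floor only: an at least 1.0-fold higher number from compound 3 to compound 4 (0.01 log units; that floor lies within the scatter), and an at least 1.0-fold higher number from compound 1 to compound 4 (0.02 log units; that floor lies within the scatter). Unlike the step between methoxy and methyl, where both ends are numbers, these two steps have no measured size, so the phenyl compound can be placed level with its neighbours or well past them. The 4-methylphenyl to phenyl change also moves this series onto the assay's ceiling, which now holds a second compound: the limit of > 800000 nM in this assay, at which 2 of the 4 values shown sit.

On these data alone, how far the true value of compound 4 lies from compound 3 remains unknown, since a limit gives no number to compare. Also open, as far as these compounds go, is whether an amine or a carboxylic acid on this aromatic carbon would give a value clearly lower than those of compound 1 and compound 3.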